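A few compounds are considered here, and "the series" means these few. Any claim that something is new, unique, unknown or untested is made for them only; others in the source may bear on it.

Measured compounds:
compound 1 `COc1cccc(/C=C/c2ccccc2O)c1` — 26 ug/mL
compound 2 `COc1ccc(/C=C/c2ccccc2O)cc1` — 10 ug/mL
compound 3 `COc1cccc(/C=C/c2ccccc2N)c1` — 21.2 ug/mL

All three values come from a functional assay on HT-29 cells (Homo sapiens) for inhibition, read by MTT assay, with a stated time of 2 days; on this read-out higher numbers stand for weaker inhibition and lower numbers for stronger inhibition. Compound 1 and compound 2 are built from the same atoms joined differently; the difference between the two cores is not broken down here. Compound 2 gives the lowest number of the three, and both compound 3 and compound 1 sit beyond the scatter above it. Compound 3 is compound 1 with amino in place of hydroxy on an aromatic carbon, and that step, a 1.2-fold lower number from compound 1 to compound 3 (0.09 log units; within the scatter), stays within the scatter. Compound 4 `COc1ccc(/C=C/c2ccccc2N)cc1` is the unmeasured counterpart of compound 2 carrying the same change, (amino in place of hydroxy on an aromatic carbon). Because a 1.2-fold lower number from compound 1 to compound 3 (0.09 log units; within the scatter), the step for compound 4 is expected to be a 1.1-fold lower number from compound 2 to compound 4 (0.05 log units; within the scatter), a near-flat move in this assay. Compound 4 is therefore estimated at 9 ug/mL. The expected range for compound 4 runs from 4.5 ug/mL to 18 ug/mL.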

Compound 4, half-maximal inhibitory concentration: 73 ug/mL
For compound 4 the middle estimate is 8.1-fold (0.91 log units) below the measured one; the whole stated range lies below it.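

In this assay, amino in place of hydroxy on an aromatic carbon gives a 7.3-fold higher number from compound 2 to compound 4 (0.86 log units; beyond the scatter), and the two cores do not respond alike to this change: the same change on two cores in this assay, a 1.2-fold lower number (0.09 log units; within the scatter) from compound 1 to compound 3 and a 7.3-fold higher number (0.86 log units; beyond the scatter) from compound 2 to compound 4, 9.0-fold (0.95 log units) apart, beyond the scatter of two such steps

The near-flat step on the core of compound 1 therefore cannot be carried over to the core of compound 2 in this series. These two pairs show that the outcome of the change depends on the core, but they do not show which feature of the cores sets the difference, nor do they give a rule for any other core.

Still open, from the compounds shown here alone, is how an acetamido group or a fluorine on the same aromatic carbon would behave on each core. Also open, going by these compounds, is whether such groups would split the two cores in the same way.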